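The source may report more compounds than this note shows. Statements on the series, on what has been measured and on what is new or still open speak of the compounds shown alone.

Measured in an in vitro ADME assay on microsomes from liver (Rattus norvegicus) for metabolic stability, tested at 1 uM; on this read-out higher numbers stand for a longer-lived compound and lower numbers for a shorter-lived compound:
- compound 1 `O=C(c1cccnc1)N1CCC(NS(=O)(=O)c2cc(S(=O)(=O)c3ccccc3)ccc2C(F)(F)F)CC1`: 0.0333 h
- compound 2 `CC(C)(O)CCN1CCC(NS(=O)(=O)c2cc(S(=O)(=O)c3ccccc3)ccc2C(F)(F)F)CC1`: 0.05 h

Compound 2, at 0.05 h, cannot be told apart from compound 1, at 0.0333 h. The next structure, compound 3 `O=C(C1CCNCC1)N1CCC(NS(=O)(=O)c2cc(S(=O)(=O)c3ccccc3)ccc2C(F)(F)F)CC1`, differs from compound 2 on an amine nitrogen in a ring: (piperidin-4-yl)carbonyl in place of 3-hydroxy-3-methylbutyl on an amine nitrogen in a ring. Within the data shown here, only one measured step bears on this place, a 1.5-fold higher number from compound 1 to compound 2 (0.18 log units; within the scatter), and it lies within the scatter. Compound 3 also has a carbonyl on that nitrogen, as compound 1 does, so neither group gives reason to expect a real shift. The step expected in this assay is no change at the digits printed from compound 2 to compound 3 (within the scatter), none beyond the scatter. Compound 3 is estimated at 0.05 h, with an expected range of 0.025 h to 0.12 h.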

Compound 3, half-life: > 0.5 h
Compound 3: no number, only a limit (the forecaster's own chance of this, stated with the estimate: 10%); middle value at least 10-fold (1.00 log units) away from the limit.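

Compound 3 reads > 0.5 h in this assay, which is a limit of the assay and not a number. The amine nitrogen in the ring can move this read-out after all, with an at least 10-fold higher number from compound 2 to compound 3 (1.00 log units; beyond the scatter). A carbonyl on that nitrogen is not enough by itself: compound 1 carries one too, and piperidin-4-yl in place of pyridin-3-yl on the carbonyl carbon gives an at least 15-fold higher number from compound 1 to compound 3 (1.17 log units; beyond the scatter).

Going by these compounds, how far past the limit compound 3 lies stays open, and so does the full size of both steps. Also open, on these data alone, is whether the nitrogen inside piperidin-4-yl matters, which a cyclohexylcarbonyl group, with an all-carbon ring, would test.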